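Swapping the Amine Side Chain on an Anilide Quinoline Core

The compounds below may be only part of what the source reports. "The series", "measured", "known", "first", "only" and "open" are said of these compounds alone.

Measured so far:
compound 1, `Cc1cc(NCCN(C)C)nc2ccc(NC(=O)c3ccc(Cl)c(Cl)c3)cc12`, 2550 nM
compound 2, `CCN1CCN(c2cc(C)c3cc(NC(=O)c4ccccc4C)ccc3n2)CC1`, 10900 nM

In a functional assay on MCF7 cells (Homo sapiens) for antiproliferative activity, read by MTT assay, with a stated time of 72 h (on this read-out lower numbers stand for stronger inhibition and higher numbers for weaker inhibition), compound 1 gives 2550 nM, the lowest of the two numbers. Among the measured compounds shown here, compound 2 has the higher number, 10900 nM, and the gap between these two values is beyond the scatter; since the two compounds differ in more than one place, the two values alone show only that compound 1 is the stronger of the pair. The unmeasured compound 3, `CCN1CCN(c2cc(C)c3cc(NC(=O)c4ccc(Cl)c(Cl)c4)ccc3n2)CC1`, keeps the dichlorobenzoyl amide of compound 1 and changes only the amine group on the shared core: 4-ethylpiperazin-1-yl in place of (2-(dimethylamino)ethyl)amino on an aromatic carbon. For the measured compounds named here, no measured pair isolates this exchange, so the size of the step from compound 1 to compound 3 is open. Compound 2 carries the same 4-ethylpiperazin-1-yl group as compound 3 and is weaker than compound 1, but its amide also differs, so this is only a loose hint toward a somewhat weaker compound 3. The expected step is a 1.6-fold higher number from compound 1 to compound 3 (0.20 log units; within the scatter), modest and likely within or just beyond the scatter. Compound 3 is estimated at 4000 nM, with a range from 1300 nM to 12000 nM.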

Compound 3, half-maximal inhibitory concentration in the MCF7 assay: 1380 nM
Estimate against measurement, compound 3: 2.9-fold (0.46 log units) above; low and high end bracket the measured number.
By their numbers in the MCF7 assay, from the lowest: compounds 3 and 1 (each within the scatter of the next); then compound 2.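

On this aromatic carbon next to the ring nitrogen, putting 4-ethylpiperazin-1-yl in place of (2-(dimethylamino)ethyl)amino gives in the MCF7 assay a 1.8-fold lower number from compound 1 to compound 3 (0.27 log units; within the scatter) and so leaves the ring and the open chain indistinguishable on this read-out. With 4-ethylpiperazin-1-yl held fixed, the amide side accounts for the clear difference in the MCF7 assay as 3,4-dichlorophenyl in place of 2-methylphenyl on a carbonyl carbon gives a 7.9-fold lower number from compound 2 to compound 3 (0.90 log units; beyond the scatter) and thus shows that the weakness of compound 2 does not come from its piperazine. The same amine exchange is far from neutral in a physicochemical assay for solubility (a higher number here means a more soluble compound, a lower number a less soluble compound), where compound 1 gives 122 ug/mL and compound 3 gives 11.3 ug/mL so the change leaves cell potency within the scatter but lowers solubility: the measured solubility of compound 1, 122 ug/mL, and of compound 3, 11.3 ug/mL, an 11-fold lower number (1.03 log units; beyond the scatter).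

The compounds shown leave open whether a morpholine ring or a longer aminoalkyl chain on this carbon would hold the number in the MCF7 assay while keeping more of the solubility seen for compound 1. They also leave open whether the amide step would be of similar size with (2-(dimethylamino)ethyl)amino on the shared core.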